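Chain extension in a sulfonamide carboxylic acid series

A few compounds are considered here, and "the series" means these few. Any claim that something is new, unique, unknown or untested is made for them only; others in the source may bear on it.

Measured in a functional assay (aorta) for inhibition, with Rattus norvegicus as the target; on this read-out lower numbers stand for stronger inhibition and higher numbers for weaker inhibition:
- Compound 1 `O=C(O)CCCCCCCNS(=O)(=O)c1ccccc1`: 2800 nM
- Compound 2 `O=C(O)CCCCCCCCNS(=O)(=O)c1ccccc1`: 1600 nM

Within the data shown here, compound 2, at 1600 nM, stands within the scatter of compound 1, the only other measured compound, so the two cannot be ranked. The next case is compound 3 `O=C(O)CCCCCCCCCCNS(=O)(=O)c1ccccc1`. The change from compound 2 is 2-carboxyethyl in place of carboxy on a saturated chain carbon, eight bonds along the chain from a sulfonamide nitrogen. Cut one bond further out, the same difference reads carboxymethyl to 3-carboxypropyl.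

Among the measured compounds shown here, only one measured step bears on this. It shows a 1.8-fold lower number from compound 1 to compound 2 (0.24 log units; within the scatter), with carboxymethyl in place of carboxy on the same chain. That step lies within the scatter, and a single step establishes no trend with chain length. The change to compound 3 also goes further along the chain than the measured step did, so the data do not cover it directly. In this assay, no step beyond the scatter is expected, and no firm direction can be assigned. The estimated step is a 1.5-fold lower number from compound 2 to compound 3 (0.16 log units; within the scatter). For compound 3 the expected value is 1100 nM, with an estimated range of 350 nM to 3500 nM.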

Compound 3, half-maximal inhibitory concentration: 4600 nM
The estimate for compound 3 lay 4.2-fold (0.62 log units) below the measured number; measured number outside the range, above it.
By their numbers in this assay, from the lowest: compounds 2, 1 and 3 (each within the scatter of the next, the first and the last beyond it).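

In this assay, among these compounds, 2-carboxyethyl in place of carboxy on a saturated chain carbon, eight bonds along the chain from a sulfonamide nitrogen, gives the first step that lies beyond the scatter: a 2.9-fold higher number from compound 2 to compound 3 (0.46 log units; beyond the scatter), a modest change. Chain extension at this place is therefore not neutral in every case, and the lower number seen with compound 2 does not carry through to compound 3, though compound 2 itself remains within the scatter of compound 1. The other step, a 1.6-fold higher number from compound 1 to compound 3 (0.22 log units; within the scatter), lies within the scatter, so those two compounds cannot be ranked, and no supporting data bear on why the chain change acts in this way.

Going by these compounds, whether compound 2 marks a true low point stays open, as the case rests on one modest step and compound 2 cannot be separated from compound 1. On these data alone, what a longer chain than that of compound 3 would do, or an amide in place of the carboxylic acid, also stays open.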